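This account rests on a few compounds, and the source may have more. Where it says the series, first, only, none or still open, it means among the compounds named here.

Series notes. Of the compounds shown here, two of the shared core have been measured in a functional assay on the whole organism for inhibition of sodium-dependent dopamine transporter (Mus musculus); a lower number here means that less compound is needed, a higher number that more compound is needed for the effect. Compound 1 `CN1Cc2c(N)cccc2C(c2ccc(F)cc2)C1` gives 7.5 mg/kg in this assay. Compound 2 `CCCNC(=O)Nc1cccc2c1CN(C)CC2c1ccccc1` stands at a limit only: in this assay compound 2 gives > 120 mg/kg, which is a limit of the assay and not a number, as the limit of > 120 mg/kg in this assay, at which 1 of the 2 values shown sits, records. Among the measured compounds shown here, no step between measured compounds that differ in one place is available, so compound 2 is placed by its limit alone and its distance from compound 1 cannot be put into a number.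

Compound 3 `CCOC(=O)Nc1cccc2c1CN(C)CC2c1ccccc1` is the next one to be measured. It differs from compound 2 by ethoxy in place of propylamino on a carbonyl carbon. For the measured compounds named here, no measured step of this kind is at hand, so the size of the step in this assay can only be estimated from the limit of compound 2. The expected step is an at least 1.2-fold lower number from compound 2 to compound 3 (0.07 log units; that floor lies within the scatter), small and in no clear direction beyond the usual scatter. For compound 3 the estimate in this assay is 100 mg/kg, with a range from 30 mg/kg to 300 mg/kg; a reading that is again only a limit is expected to be about as likely as a number.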

Compound 3, dose for half-maximal effect: 2.5 mg/kg
For compound 3 the middle estimate is 40-fold (1.60 log units) above the measured one; measured number below the stated range.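

Among the compounds shown here, on the carbonyl carbon whose other neighbours are an amide-type nitrogen, the exchange of propylamino for ethoxy gives the first one-place comparison, and in this assay it produces an at least 48-fold lower number from compound 2 to compound 3 (1.68 log units; beyond the scatter). This position is therefore not indifferent to what sits on the carbonyl carbon: a change of a single group, with the donor of propylamino leaving and the acceptor of ethoxy entering, separates a compound with a measured dose from one that has only a limit. The size of the step is a floor and not a measured distance, since compound 2 stands at a limit of the assay: the limit of > 120 mg/kg in this assay, at which 1 of the 3 values shown sits.

The compounds shown leave open whether the step follows the exchange of nitrogen for oxygen or the shorter chain, and ethylamino or propoxy on the same carbonyl carbon would separate the two. For the compounds shown here, compound 1 differs from compound 3 in more than one place, so no step between them can be read, and the separate contribution of the amine and of the fluorine in compound 1 stays unknown.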